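Removing the Acyl Group and Swapping Trifluoromethyl for Hydroxy

The source may report more compounds than this note shows. Statements on the series, on what has been measured and on what is new or still open speak of the compounds shown alone.

Compound 1, `O=C(Nc1ccccc1O)C1CCc2ccccc2N1C(=O)c1ccc(Cl)cc1`: 13400 nM
Compound 2, `O=C(Nc1ccccc1C(F)(F)F)C1CCc2ccccc2N1`: 39300 nM
Compound 3, `O=C(Nc1ccccc1C(F)(F)F)C1CCc2ccccc2N1C(=O)c1ccc(Cl)cc1`: 551 nM

All three were tested in a functional assay on NUGC-3 cells (Homo sapiens) for cytotoxicity, read by sulforhodamine B assay, with a stated time of 72 h; a lower number here means a stronger inhibitor of growth, a higher number a weaker inhibitor of growth. Compound 2 shows the highest number of the three, making it the weakest growth inhibitor; compound 1 stands nearest to it and compound 3 furthest away. Compound 4, `O=C(Nc1ccccc1O)C1CCc2ccccc2N1`, differs from compound 2 by hydroxy in place of trifluoromethyl on an aromatic carbon. Among the compounds with values here, one measured step bears on this change: from compound 1 to compound 3, where trifluoromethyl replaced hydroxy on a core carrying the (4-chlorophenyl)carbonyl group, the number fell sharply, a 24-fold lower number from compound 1 to compound 3 (1.39 log units; beyond the scatter). Compound 4 makes the reverse exchange on a core with hydrogen on that nitrogen, so a large rise in this assay is expected, toward weaker inhibition, as a 6.4-fold higher number from compound 2 to compound 4 (0.80 log units; beyond the scatter). Compound 4 is therefore estimated at 250000 nM, within a range from 60000 nM to 1000000 nM.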

Compound 4, concentration for 50% growth inhibition: 2680 nM
The estimate for compound 4 lay 93-fold (1.97 log units) above the measured number; the whole stated range lies above it.
By their numbers in this assay, from the lowest: compound 3; then compound 4; then compound 1; then compound 2.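

In this assay, hydroxy in place of trifluoromethyl on this aromatic carbon gives a 15-fold lower number from compound 2 to compound 4 (1.17 log units; beyond the scatter), so the exchange reverses direction once the (4-chlorophenyl)carbonyl group is gone: the same change on two cores in this assay, a 24-fold lower number (1.39 log units; beyond the scatter) from compound 1 to compound 3 and a 15-fold higher number (1.17 log units; beyond the scatter) from compound 4 to compound 2, 360-fold (2.55 log units) apart, beyond the scatter of two such steps

Removing that group with hydroxy in place gives a 5.0-fold lower number from compound 1 to compound 4 (0.70 log units; beyond the scatter), the opposite of its effect with trifluoromethyl present: the same change on two cores in this assay, a 71-fold lower number (1.85 log units; beyond the scatter) from compound 2 to compound 3 and a 5.0-fold higher number (0.70 log units; beyond the scatter) from compound 4 to compound 1, 360-fold (2.55 log units) apart, beyond the scatter of two such steps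

The effect of each change therefore depends on the other.

The compounds shown do not tell why the two changes interact. From the compounds shown here alone, whether an amine or a methoxy group at this place would follow hydroxy also remains open.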